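The compounds below may be only part of what the source reports. "The series", "measured", "known", "first", "only" and "open" are said of these compounds alone.

Compound 1 `COc1ccc(Nc2n[nH]c(-c3cccnc3Nc3cc(OC)cc(OC)c3)n2)cc1` gives 68% in a functional assay on A-431 cells (Homo sapiens), tested at 0.1 uM; a lower number here means less inhibition, a higher number more inhibition at the concentration tested (going by the name of the read-out). Compound 2 `COc1cc(Nc2ncccc2-c2nc(Nc3cc(OC)ccc3OC)n[nH]2)cc(OC)c1` gives 20% in this assay, and compound 3 `COc1cc(Nc2ncccc2-c2nc(Nc3ccc(OC)cc3OC)n[nH]2)cc(OC)c1` gives 17% in this assay, the lowest of the three numbers; the step of a number 3 percentage points lower from compound 2 to compound 3 (within the scatter) lies within the scatter, whereas a number 48 percentage points lower from compound 1 to compound 2 (beyond the scatter) and a number 51 percentage points lower from compound 1 to compound 3 (beyond the scatter) are both large. Compound 4 `COc1cccc(CNc2n[nH]c(-c3cccnc3Nc3cc(OC)cc(OC)c3)n2)c1` differs from compound 3 by 3-methoxybenzyl in place of 2,4-dimethoxyphenyl on a nitrogen on an aromatic ring. Of the measured steps, a number 3 percentage points lower from compound 2 to compound 3 (within the scatter) shows that changing the methoxy pattern of the phenyl on that nitrogen altered little, while a number 48 percentage points lower from compound 1 to compound 2 (beyond the scatter) shows that the group itself matters strongly. Among the measured compounds shown here, no measured step replaces phenyl by benzyl, so the direction is open. Compound 4 is expected to give 35% in this assay, within 10% to 65%, a step of a number 18 percentage points higher from compound 3 to compound 4 (beyond the scatter) estimated as modestly upward.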

Compound 4, a percentage reported as inhibition, at one concentration (the size of the read-out at that concentration, not a potency): 71%
Compound 4: the middle estimate sits 36 percentage points below what was measured; the whole stated range lies below it.
By their numbers in this assay, from the lowest: compounds 3 and 2 (each within the scatter of the next); then compounds 1 and 4 (each within the scatter of the next).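

In this assay, 3-methoxybenzyl in place of 2,4-dimethoxyphenyl gives a number 54 percentage points higher from compound 3 to compound 4 (beyond the scatter) and in place of 2,5-dimethoxyphenyl gives a number 51 percentage points higher from compound 2 to compound 4 (beyond the scatter) on this nitrogen, so a benzyl group can carry the high number here, which the phenyl-only compounds could not show. In place of 4-methoxyphenyl it gives a number 3 percentage points higher from compound 1 to compound 4 (within the scatter) and thus no readable change, so the low numbers belong to the two dimethoxyphenyl compounds, not to every departure from 4-methoxyphenyl. No supporting data explain this result.

Still open, going by these compounds, is whether the benzyl needs its methoxy group, and whether a longer chain such as 2-phenylethyl or a morpholine on this nitrogen keeps the number.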